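This account rests on a few compounds, and the source may have more. Where it says the series, first, only, none or still open, it means among the compounds named here.

Measured in a functional assay on SNB-19 cells (Homo sapiens) for inhibition, read by sulforhodamine B assay, with a stated time of 48 h; on this read-out higher numbers stand for weaker inhibition of growth and lower numbers for stronger inhibition of growth:
- compound 1, `Nc1cc(N)c2nc(-c3ccccc3)c(Oc3ccc(Cl)c(Cl)c3)nc2c1`: 52500 nM
- compound 2, `CCOC(=O)[C@H](CCC(=O)O)NC(=O)c1ccc(Sc2nc3cc(N)cc(N)c3nc2-c2ccccc2)cc1`: compound 2 gives < 100000 nM, which is a limit of this assay and not a number
- compound 3, `COc1cc(CNc2nc3cc(N)cc(N)c3nc2-c2ccccc2)cc(OC)c1OC`: 20900 nM

Among the two plain numbers, compound 1 has the higher one, so compound 1 is the weaker grower-inhibitor of the pair. Its nearest neighbour is compound 3, whose lower number lies beyond the usual scatter of repeat measurements. Within the data shown here, the third result, that of compound 2, sits at the limit of < 100000 nM in this assay, at which 1 of the 3 values shown sits, and tells only that the true number lies somewhere under that line.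

Compound 4, `Nc1cc(N)c2nc(-c3ccccc3)c(Sc3ccc(Cl)c(Cl)c3)nc2c1`, has not yet been measured in this assay. It differs from compound 1 in one place: (3,4-dichlorophenyl)sulfanyl in place of 3,4-dichlorophenoxy on an aromatic carbon. The shared core, the phenyl group and the two chlorines on the outer ring all stay as they are; only the single atom linking the outer ring to the core changes, from oxygen to sulfur.

Among the measured compounds shown here, no pair of measured compounds differing in one place is available to calibrate this change. The expected step from compound 1 to compound 4 is therefore taken as small, a 1.3-fold lower number from compound 1 to compound 4 (0.12 log units; within the scatter), pointing toward a slightly lower number, and is not expected to reach beyond the scatter. On that basis compound 4 is estimated at 40000 nM, within a range from 15000 nM to 120000 nM.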

Compound 4, concentration for total growth inhibition: 57500 nM
Beside the measured number, compound 4's estimate is 1.4-fold (0.16 log units) below it; low and high end bracket the measured number.
By their numbers in this assay, from the lowest: compound 3; then compounds 1 and 4 (each within the scatter of the next).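

Among these compounds, putting (3,4-dichlorophenyl)sulfanyl in place of 3,4-dichlorophenoxy on this aromatic carbon gives, in this assay, a 1.1-fold higher number from compound 1 to compound 4 (0.04 log units; within the scatter) and so supplies the first measured pair of compounds that differ in one place. Among the compounds shown here, at this position, with this outer ring, oxygen and sulfur as the linking atom cannot be told apart on this read-out, which the earlier compounds, differing in more than one place, could not show. Nothing in the data shown bears on why the two linking atoms give results within the scatter of each other.

Going by these compounds, whether a sulfone or a carbonyl as the link at this position would give a similar number remains open. So does whether the same swap would stay within the scatter if a nitrile replaced the two chlorines on the outer ring.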